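The source may hold more compounds than are shown below. What is called first, only, known or untested is meant among the compounds shown, and "the series" means these compounds.

Three compounds of the series carry a number or a limit in an ADME assay on CEM-SS cells (Homo sapiens) for cytotoxicity, read by XTT assay, with a stated time of 6 days (on this read-out higher numbers stand for lower toxicity in this test and lower numbers for higher toxicity in this test), and the account here concerns the change from compound 2 to compound 4. Compound 1 `CCCC(=O)OCSc1ccc(OC(F)(F)F)cc1C(=O)NC(C)(C)C(N)=O` reaches only a limit in this assay, where compound 1 gives < 56.1 uM. Compound 2 `CCCC(=O)OCSc1ccccc1C(=O)NCCCNC(C)=O` gives 21.1 uM in this assay. Compound 3 `CCCC(=O)OC[Se]c1ccccc1C(=O)NCCC(N)=O` gives 10.5 uM in this assay. Within the data shown here, compound 2 and compound 3 are the only two compounds with a number, and the gap between them lies within the usual scatter of this assay, so neither can be set apart from the other. Compound 2 therefore stands among the numbers as one of two that cannot be told apart.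

Compound 4 `C#CCNC(=O)CNC(=O)c1ccccc1SCOC(=O)CCC` has not yet been measured. It differs from compound 2 in one place (propargylcarbamoyl in place of 2-acetamidoethyl on a saturated chain carbon bound to an amide-type nitrogen). The part that leaves and the part that enters are each counted as six heavy atoms, each with one hydrogen-bond donor and one hydrogen-bond acceptor, and the whole change sits far from the shared core of compound 2. Among the measured compounds shown here, no measured step of this kind exists to lean on. The expected step of a 1.1-fold lower number from compound 2 to compound 4 (0.02 log units; within the scatter) is none beyond the scatter, in either direction. Compound 4 is accordingly estimated at 20 uM in this assay, with a range from 8 uM to 50 uM.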

Compound 4, half-maximal toxic concentration: 95.4 uM
Estimate against measurement, compound 4: 4.8-fold (0.68 log units) below; measured number outside the range, above it.
By their numbers in this assay, from the lowest: compounds 3 and 2 (each within the scatter of the next); then compound 4.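

In this assay, propargylcarbamoyl in place of 2-acetamidoethyl on a saturated chain carbon bound to an amide-type nitrogen gives a 4.5-fold higher number from compound 2 to compound 4 (0.66 log units; beyond the scatter). Among these compounds, this is the first step that can be read at all, and it shows that the number in this test responds to what this position carries, even though the change sits far from the shared core. The leaving and entering groups match in their counts of heavy atoms, hydrogen-bond donors and hydrogen-bond acceptors, so those counts do not separate them, and nothing shown here accounts for the size of the step.

The compounds shown leave open which part of the entering group goes with the higher number, since the triple bond and the rearranged amide arrive together and a saturated propylcarbamoyl group would be needed to pull them apart. They also leave open how this position would respond to a simple amine or a carboxylic acid at the end of the chain, and whether the same change would give a similar step on another core.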